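This account rests on a few compounds, and the source may have more. Where it says the series, first, only, none or still open, it means among the compounds named here.

Compound 1 `Nc1ncnc2c1c(-c1cnc3[nH]ccc3c1)nn2CCCCCCC(=O)NO` gives 99.1% in an assay on isolated protein for inhibition of protein deacetylase HDAC6 (Homo sapiens), with a stated time of 15 min, tested at 1 uM; on this read-out higher numbers stand for more inhibition at the one concentration tested (going by the name of the read-out) and lower numbers for less inhibition. On the numbers shown compound 1 is second highest of three, with all three within the scatter of one another. Its nearest neighbour is compound 3 `Nc1ncnc2c1c(-c1cnc3[nH]ccc3c1)nn2CCCCCCCCC(=O)NO`, which gives 99.2%, and the step of a number 0.1 percentage points higher from compound 1 to compound 3 (within the scatter) is within the scatter. Compound 2 `Nc1ncnc2c1c(-c1cnc3[nH]ccc3c1)nn2CCCCCCCCCC(=O)NO` gives 98.3%; the step of a number 0.8 percentage points lower from compound 1 to compound 2 (within the scatter) is likewise within the scatter, as is a number 0.9 percentage points higher from compound 2 to compound 3 (within the scatter). Compound 4 `Nc1nc2cc(-c3nn(CCCCCCC(=O)NO)c4ncnc(N)c34)ccc2o1` differs from compound 1 by a group of 10 heavy atoms (7 carbon, 2 nitrogen, 1 oxygen; one five-membered aromatic ring with 2 hetero atoms, one six-membered aromatic ring of carbon only) in place of a group of 9 heavy atoms (7 carbon, 2 nitrogen; one five-membered aromatic ring with 1 hetero atom, one six-membered aromatic ring with 1 hetero atom), on an aromatic carbon. The measured steps all alter the chain bearing the hydroxycarbamoyl group and leave the aryl group untouched, so none bears on this change. With every measured value near the ceiling, a step of a number 7.1 percentage points lower from compound 1 to compound 4 (within the scatter) is expected that stays within the scatter, though the untested replacement widens the range downward. Compound 4 is estimated at 92%, between 60% and 99.5%.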

Compound 4, a percentage reported as inhibition, at one concentration (the size of the read-out at that concentration, not a potency): 99%
Estimate against measurement, compound 4: 7 percentage points below, and the stated range covers the measured number.
By their numbers in this assay, from the lowest: compounds 2, 4, 1 and 3 (each within the scatter of the next).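

With the chain held constant, the step to 2-amino-1,3-benzoxazol-5-yl on the aromatic carbon gives a number 0.1 percentage points lower from compound 1 to compound 4 (within the scatter) in this assay. Among the compounds shown here, this is the first information on this position: the two groups cannot be told apart here at the one concentration tested, so the position accepts either at that concentration. Nothing on hand explains this result.

Values this close to the top of the read-out give no ranking of potency between the two groups. As far as these compounds go, whether a plain phenyl ring or a shorter chain would hold the inhibition remains open.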